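Moving a fluorine on a shared core in three compounds

The source may hold more compounds than are shown below. What is called first, only, known or untested is meant among the compounds shown, and "the series" means these compounds.

So far, compound 1, compound 2 and compound 3 have been tested in a functional assay on SMMC-7721 cells (Homo sapiens) for antiproliferative activity, read by MTT assay, with a stated time of 72 h; on this read-out lower numbers stand for stronger inhibition and higher numbers for weaker inhibition. Compound 1 `Cc1nn(C)c(Oc2cccc(F)c2)c1/C=N\CCCCCOc1cc2oc(=O)cc(C)c2cc1Cl` gives 11800 nM in this assay. Compound 2 `Cc1nn(C)c(Oc2ccc(F)cc2)c1/C=N\CCCCCOc1cc2oc(=O)cc(C)c2cc1Cl` gives 22100 nM in this assay. Compound 3 `Cc1nn(C)c(Oc2cccc(F)c2)c1/C=N\CCCCCCOc1cc2oc(=O)cc(C)c2cc1Cl` gives 23600 nM in this assay, and compound 4 `Cc1nn(C)c(Oc2ccc(F)cc2)c1/C=N\CCCCCCOc1cc2oc(=O)cc(C)c2cc1Cl` has not yet been measured in it.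

Compound 1 and compound 2 differ in one place: 4-fluorophenyl in place of 3-fluorophenyl on an oxygen on an aromatic ring. This change produced a 1.9-fold higher number from compound 1 to compound 2 (0.27 log units; within the scatter), so the two values cannot be told apart with confidence. Compound 3 and compound 4 differ by the very same change, at the same place: 4-fluorophenyl in place of 3-fluorophenyl on an oxygen on an aromatic ring. How the core of compound 3 differs from the core of compound 1 is not broken down here; the two compounds simply sit where their values put them, within the usual scatter of each other.

Because the earlier step gave a 1.9-fold higher number from compound 1 to compound 2 (0.27 log units; within the scatter), a step of similar size is expected from compound 3 to compound 4, namely a 1.5-fold higher number from compound 3 to compound 4 (0.18 log units; within the scatter). On that basis compound 4 is expected to give about 36000 nM in this assay, estimated to lie between 15000 nM and 85000 nM.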

Compound 4, half-maximal inhibitory concentration: 13500 nM
Compound 4: the middle estimate sits 2.7-fold (0.43 log units) above what was measured; measured number below the stated range.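

In this assay, putting 4-fluorophenyl in place of 3-fluorophenyl on the core of compound 3 gives a 1.7-fold lower number from compound 3 to compound 4 (0.24 log units; within the scatter). Set beside the earlier step, this shows that the same swap did not carry over from one core to the other with the same size and direction: the same change on two cores in this assay, a 1.9-fold higher number (0.27 log units; within the scatter) from compound 1 to compound 2 and a 1.7-fold lower number (0.24 log units; within the scatter) from compound 3 to compound 4, 3.3-fold (0.52 log units) apart, beyond the scatter of two such steps. Among these compounds, it does not show why the two cores differ, and it does not rank the two fluorophenyl groups, since each step taken alone is within the scatter and only one pair of steps is available for comparison.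

The compounds shown leave open whether the swap would follow either step on a core with a longer chain, which would help show how far the result depends on the core. They also leave open how a plain phenyl or a 4-chlorophenyl group would compare with the two fluorophenyl groups at the same place.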